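A few compounds are considered here, and "the series" means these few. Any claim that something is new, unique, unknown or untested is made for them only; others in the source may bear on it.

Compound 1 `CCCCCCCCNc1nc(SCc2ccc(C(F)(F)F)cc2)nc2ccccc12` has the lowest number of the three compounds measured in a functional assay on PC-3 cells (Homo sapiens) for cytotoxicity, read by MTT assay, with a stated time of 72 h (on this read-out lower numbers stand for stronger inhibition and higher numbers for weaker inhibition), where compound 1 gives 10500 nM. Compound 2 `FC(F)(F)c1ccc(CSc2nc(Nc3ccccc3Cl)c3ccccc3n2)cc1` gives 20400 nM in this assay, and compound 3 `Cc1ccccc1Nc1nc(SCc2ccc(C(F)(F)F)cc2)nc2ccccc12` gives 36900 nM. The step of a 1.9-fold higher number from compound 1 to compound 2 (0.29 log units; within the scatter) lies within the scatter, whereas a 3.5-fold higher number from compound 1 to compound 3 (0.55 log units; beyond the scatter) is a modest change beyond it; between compound 2 and compound 3, a 1.8-fold higher number from compound 2 to compound 3 (0.26 log units; within the scatter) stays within the scatter. Compound 4 `FC(F)(F)c1ccc(CSc2nc(Nc3cccc(C(F)(F)F)c3)c3ccccc3n2)cc1` has not yet been measured. It differs from compound 1 in one place: 3-(trifluoromethyl)phenyl in place of octyl on a nitrogen on an aromatic ring. The two measured steps that bear on this change are those in which a six-membered aromatic ring took the place of the octyl chain, leading to compound 2 and to compound 3; both gave higher numbers, one within and one beyond the scatter. For compound 4 a step of that kind is therefore expected in this assay, namely a 2.1-fold higher number from compound 1 to compound 4 (0.32 log units; beyond the scatter), toward a higher number. Compound 4 is estimated at 22000 nM, within a range from 9000 nM to 55000 nM.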

Compound 4, half-maximal inhibitory concentration: 12900 nM
Estimate against measurement, compound 4: 1.7-fold (0.23 log units) above; the range from low to high includes it.
By their numbers in this assay, from the lowest: compounds 1, 4, 2 and 3 (each within the scatter of the next, the first and the last beyond it).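

With 3-(trifluoromethyl)phenyl on this nitrogen, a 1.2-fold higher number from compound 1 to compound 4 (0.09 log units; within the scatter) shows that a ring carrying this larger group can replace the octyl chain with no change beyond the scatter in this assay. Among the compounds shown here, what is new is that the choice among aromatic groups can matter here: a 2.9-fold lower number from compound 3 to compound 4 (0.46 log units; beyond the scatter) is the first step between two such groups to pass beyond the scatter. Not every swap of this kind does so, as a 1.6-fold lower number from compound 2 to compound 4 (0.20 log units; within the scatter) stays within it. No measurement here explains why these groups compare as they do.

The compounds shown do not tell how a plain phenyl ring, or a ring bearing an amine or a carboxylic acid, would behave on this nitrogen. They also leave open whether a chain longer or shorter than octyl would give a lower number than compound 1.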